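Lengthening one chain segment in a small polyamine

The source may report more compounds than this note shows. Statements on the series, on what has been measured and on what is new or still open speak of the compounds shown alone.

Measured in a functional assay on L1210 cells (Mus musculus) for inhibition, with a stated time of 96 h; a lower number here means a stronger inhibitor, a higher number a weaker inhibitor:
- compound 1 `CCCNCCCNCCCNCCC`: 60000 nM
- compound 2 `CNCCCCNCCCNC`: 1700 nM
- compound 3 `CCNCCCCNCCCN`: 40000 nM

Compound 1, at 60000 nM, sits at the high end of these numbers together with compound 3, at 40000 nM, and the two lie within the scatter of each other. Compound 2, at 1700 nM, is a far stronger inhibitor than compound 1, beyond the scatter.

The next compound is compound 4 `CCCNCCCCNCCCNCCC`. It differs from compound 1 by (propylamino)methyl in place of propylamino on a saturated chain carbon, three bonds along the chain from an amine nitrogen.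

Within the data shown here, no measured pair shows this change alone, so the guide is indirect. Compound 2, at 1700 nM, and compound 3, at 40000 nM, both contain the longer chain stretch, yet their values sit far apart. A moderate gain in this assay therefore seems likeliest, with wide uncertainty. The expected change is a 7.5-fold lower number from compound 1 to compound 4 (0.88 log units; beyond the scatter). Compound 4 is estimated at 8000 nM, within a range of 1500 nM to 40000 nM.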

Compound 4, half-maximal inhibitory concentration: 33000 nM
Compound 4: middle estimate off by 4.1-fold (0.62 log units), on the low side; the range from low to high includes it.
By their numbers in this assay, from the lowest: compound 2; then compounds 4, 3 and 1 (each within the scatter of the next).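

In this assay, among these compounds, putting (propylamino)methyl in place of propylamino on a saturated chain carbon, three bonds along the chain from an amine nitrogen, gives a 1.8-fold lower number from compound 1 to compound 4 (0.26 log units; within the scatter) and so provides the first direct reading of this change. The one-carbon lengthening of this chain segment therefore makes no real difference to inhibition in this pair of compounds. No measurement here offers an explanation for this result.

This single pair cannot show whether the same lengthening would matter in a polyamine with different end groups on its nitrogens. Also open, from the compounds shown here alone, is how this assay would respond to a still longer chain at this place, or to a hydroxyl group on it.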